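Series notes: 4-chlorobenzyl to 4-methylbenzyl in compound 4

The source may report more compounds than this note shows. Statements on the series, on what has been measured and on what is new or still open speak of the compounds shown alone.

Compound 1 `CN(C)c1ccc(C(=O)N(CCC(=O)NCc2ccc(Cl)cc2)Cc2ccc(C(=O)NO)cc2)cc1`: 460 nM
Compound 2 `COc1ccc(C(=O)N(CCC(=O)NCc2ccccc2)Cc2ccc(C(=O)NO)cc2)cc1`: 3490 nM
Compound 3 `COc1cc(OC)cc(C(=O)N(CCC(=O)NCc2ccccc2)Cc2ccc(C(=O)NO)cc2)c1`: 14700 nM

Measured in a functional assay on G55T2 cells (Homo sapiens) for antiproliferative activity, read by WST assay, with a stated time of 72 h (a higher number here means a weaker inhibitor, a lower number a stronger inhibitor), compound 1 stands lowest of the three numbers; compound 2 sits nearer to it than compound 3 does. Going by the values given here, the one single-point step measured, a 4.2-fold higher number from compound 2 to compound 3 (0.62 log units; beyond the scatter), concerns the group on the carbonyl carbon and not the 4-chlorobenzyl group. Compound 4 `Cc1ccc(CNC(=O)CCN(Cc2ccc(C(=O)NO)cc2)C(=O)c2ccc(N(C)C)cc2)cc1` differs from compound 1 only there: methyl in place of chloro on an aromatic carbon. Among the compounds with values here, no measured pair in this set shares that change, so there is nothing to scale an expectation against, and the exchange is of the smallest kind counted. The step is therefore expected to be small, a 1.3-fold higher number from compound 1 to compound 4 (0.12 log units; within the scatter), with no firm direction. Compound 4 is expected to give 600 nM, within a range from 250 nM to 1500 nM.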

Compound 4, half-maximal inhibitory concentration: 430 nM
Compound 4: middle estimate off by 1.4-fold (0.14 log units), on the high side; the range from low to high includes it.
By their numbers in this assay, from the lowest: compounds 4 and 1 (each within the scatter of the next); then compound 2; then compound 3.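

In this assay, 4-methylbenzyl in place of 4-chlorobenzyl gives a 1.1-fold lower number from compound 1 to compound 4 (0.03 log units; within the scatter), so at this aromatic carbon methyl and chloro read alike on the core of compound 1. Going by these compounds alone, this is the first step read at this end of the series, as the earlier step concerned the group on the carbonyl carbon. No evidence bears on why the two groups read alike.

Still open, going by these compounds, is whether this tolerance extends beyond these two groups, for example to an amine or a carboxylic acid on the same carbon. On these data alone, a longer chain between the aromatic ring and the amide nitrogen is also open.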